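Swapping chloro for trifluoromethyl on a chromone styryl series

The source may hold more compounds than are shown below. What is called first, only, known or untested is meant among the compounds shown, and "the series" means these compounds.

Of the compounds shown here, three with the same chromone-derived styryl scaffold have been measured in a functional assay on HeLa cells (Homo sapiens) for antiproliferative activity, read by MTT assay, with a stated time of 12 h; on this read-out lower numbers stand for stronger inhibition and higher numbers for weaker inhibition. Compound 1 `COc1cc(OC)c2c(=O)cc(/C=C/c3ccc(Cl)cc3)oc2c1` gives 14200 nM, compound 2 `COc1ccc2c(=O)cc(/C=C/c3ccc(OC(F)(F)F)cc3)oc2c1` gives 9900 nM, and compound 3 `COc1cc(/C=C/c2cc(=O)c3c(OC)cc(OC)cc3o2)cc(OC)c1` gives 16700 nM. Of these three numbers, the value of compound 1 is the second highest, yet both neighbours lie within the usual scatter, so no ordering among them is claimed. Compound 4 `COc1cc(OC)c2c(=O)cc(/C=C/c3ccc(C(F)(F)F)cc3)oc2c1` has not yet been tested in this assay. It differs from compound 1 in one place: trifluoromethyl in place of chloro on an aromatic carbon. Within the data shown here, with no measured pair showing this exchange, the step from compound 1 to compound 4 is expected to be small, a 1.2-fold lower number from compound 1 to compound 4 (0.07 log units; within the scatter), not clearly beyond the scatter in either direction. Compound 4 is therefore estimated at 12000 nM, between 5000 nM and 30000 nM.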

Compound 4, half-maximal inhibitory concentration: 19000 nM
For compound 4 the middle estimate is 1.6-fold (0.20 log units) below the measured one; measured number inside the range.
By their numbers in this assay, from the lowest: compounds 2, 1, 3 and 4 (each within the scatter of the next).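

The exchange of chloro for trifluoromethyl on this aromatic carbon, para to a large group, now has a measured step in this assay, with a 1.3-fold higher number from compound 1 to compound 4 (0.13 log units; within the scatter) as its size. At this position, therefore, the two groups cannot be told apart on this read-out. No available evidence explains the result. On these data alone, whether an amine or a carboxylic acid on this aromatic carbon would give a step beyond the scatter remains open. So does whether the same exchange would give a similar step on the core of compound 2.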